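Halogen swap on the benzothiazole side of the amide series

The compounds below may be only part of what the source reports. "The series", "measured", "known", "first", "only" and "open" are said of these compounds alone.

Measured so far in a functional assay on HT-29 cells (Homo sapiens) for cytotoxicity, read by MTT assay, with a stated time of 72 h; a lower number here means a stronger inhibitor, a higher number a weaker inhibitor:

compound 1, `O=C(Nc1nc2ccccc2s1)c1cn(-c2ccccc2)nc1-c1ccc(F)cc1`: compound 1 gives 9060 nM
compound 2, `O=C(Nc1nc2ccccc2s1)c1cn(-c2ccccc2)nc1-c1ccc(Cl)cc1`: compound 2 gives 13700 nM
compound 3, `O=C(Nc1nc2ccc(F)cc2s1)c1cn(-c2ccccc2)nc1-c1ccc(Cl)cc1`: compound 3 gives 4970 nM

Three compounds share the amide linking a pyrazole to a benzothiazole; they differ only in the halogens on the two outer rings. Compound 1 and compound 2 have the same core and differ by chloro in place of fluoro on an aromatic carbon; the step is a 1.5-fold higher number from compound 1 to compound 2 (0.18 log units; within the scatter). Compound 2 and compound 3 differ by a fluoro in place of hydrogen on an aromatic carbon of the benzothiazole, and the step is a 2.8-fold lower number from compound 2 to compound 3 (0.44 log units; beyond the scatter). Compound 3 and compound 1 differ in two places, and the difference between the two cores is not broken down here; their two values lie within the scatter of each other.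

Compound 4, `O=C(Nc1nc2ccc(Cl)cc2s1)c1cn(-c2ccccc2)nc1-c1ccc(Cl)cc1`, has not been measured in this assay. It differs from compound 3 by chloro in place of fluoro on an aromatic carbon. Going by the values given here, this is the same kind of change as the one between compound 1 and compound 2, but not the same: there the place was para to a large group on a single six-membered ring, here it is on a ring of a fused system, meta to a fused ring and para to a fused ring. Among the compounds with values here, the only guide is the earlier step, which stayed within the scatter. The step from compound 3 to compound 4 is therefore expected to be small as well, estimated at a 1.3-fold higher number from compound 3 to compound 4 (0.12 log units; within the scatter), resting on a 1.5-fold higher number from compound 1 to compound 2 (0.18 log units; within the scatter). For compound 4 the expected value is 6500 nM, estimated to fall between 3000 nM and 15000 nM.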

Compound 4, half-maximal inhibitory concentration: 4550 nM
For compound 4 the middle estimate is 1.4-fold (0.15 log units) above the measured one, within the range that was stated.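

In this assay, replacing the 6-fluoro-1,3-benzothiazol-2-yl group with 6-chloro-1,3-benzothiazol-2-yl gives a 1.1-fold lower number from compound 3 to compound 4 (0.04 log units; within the scatter), and the exchange of fluoro for chloro can now be compared on two cores: the same change on two cores in this assay, a 1.5-fold higher number (0.18 log units; within the scatter) from compound 1 to compound 2 and a 1.1-fold lower number (0.04 log units; within the scatter) from compound 3 to compound 4, 1.7-fold (0.22 log units) apart, within the scatter of two such steps. On the compounds shown, the choice of these two halogens makes no readable difference on either core, whereas adding chloro to the unsubstituted ring gives a 3.0-fold lower number from compound 2 to compound 4 (0.48 log units; beyond the scatter), a step beyond the scatter like the one for fluoro, a 2.8-fold lower number from compound 2 to compound 3 (0.44 log units; beyond the scatter). This does not show that the exchange carries over generally: it rests on two pairs, the exchange sits at a different place in each, and two steps within the scatter cannot reveal a small dependence on the core.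

Going by these compounds, it remains open how a methoxy group, an amine or a nitrile at this place on the fused system would compare with fluoro and chloro, and whether bromo would follow chloro. Also open, on these data alone, is whether the gain from adding a halogen to compound 2 would persist with fluoro in place of chloro on the outer ring of the shared core, or with a methyl group on the amide nitrogen.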